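Aryl imine swap on the shared core: tert-butyl to methoxy

The source may report more compounds than this note shows. Statements on the series, on what has been measured and on what is new or still open speak of the compounds shown alone.

Measured compounds in a functional assay on MCF7 cells (Homo sapiens) for antiproliferative activity, read by MTT assay, with a stated time of 72 h; on this read-out higher numbers stand for weaker inhibition and lower numbers for stronger inhibition:
compound 1 `COc1ccc(/C=C2\S/C(=N\c3ccc(C(C)(C)C)cc3)N(C)C2=O)cc1`: > 100000 nM
compound 2 `COc1ccc(/C=C2/CN(C)/C(=N/c3ccc(OC)cc3)S2)cc1`: 8700 nM
compound 3 `COc1ccc(/C=C2\S/C(=N\c3cc(C(F)(F)F)cc(C(F)(F)F)c3)N(C)C2=O)cc1`: 77800 nM

Compound 1 sits at the limit of this assay, (the limit of > 100000 nM in this assay, at which 1 of the 3 values shown sits); the value for compound 1 is a limit and not a number, so only an upper bound on its inhibition is known. On the same core as compound 1 but with bis(trifluoromethyl)phenyl on the imine, compound 3 gives 77800 nM. Going by the values given here, compound 2, on a different core lacking the carbonyl and carrying the methoxyphenyl imine, gives 8700 nM; no step between compound 2 and the others is counted.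

Compound 4 `COc1ccc(/C=C2\S/C(=N\c3ccc(OC)cc3)N(C)C2=O)cc1`, not yet measured, differs from compound 1 by methoxy in place of tert-butyl on an aromatic carbon. Compound 4 thus combines the core of compound 1 with the methoxyphenyl imine of compound 2.

The step from compound 1 to compound 4 is expected to go toward stronger inhibition, an at least 2.2-fold lower number from compound 1 to compound 4 (0.34 log units; beyond the scatter), beyond the scatter but only modestly, since compound 1 gives only the limit > 100000 nM. Compound 4 is expected at 45000 nM, within 12000 nM to 110000 nM.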

Compound 4, half-maximal inhibitory concentration: > 100000 nM
Compound 4: no number, only a limit; the forecaster's own chance of this, stated with the estimate: 35%; at least 2.2-fold (0.34 log units) between middle value and limit.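

Compound 1 and compound 4 both stand at a limit and not at a number, so no step can be read between them: the limit of > 100000 nM in this assay, at which 2 of the 4 values shown sit.

As far as these compounds go, whether methoxy in place of tert-butyl changes inhibition on the shared core, and in which direction, stays open.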